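The source may report more compounds than this note shows. Statements on the series, on what has been measured and on what is new or still open speak of the compounds shown alone.

Compound 1 `Cc1ccc(C(=O)NC(=S)NNc2ncnc3ccccc23)cc1`: 11200 nM
Compound 2 `O=C(NC(=S)NNc1ncnc2ccccc12)c1ccc(F)cc1`: 6070 nM
Compound 3 `O=C(NC(=S)NNc1ncnc2ccccc12)c1ccccc1Cl`: 10800 nM

In a functional assay on GLC82 cells (Homo sapiens) for cytotoxicity, read by MTT assay, with a stated time of 72 h (a lower number here means a stronger inhibitor, a higher number a weaker inhibitor), compound 3 gives the second highest of these three numbers, but its gaps to the others, a 1.0-fold lower number from compound 1 to compound 3 (0.02 log units; within the scatter) and a 1.8-fold higher number from compound 2 to compound 3 (0.25 log units; within the scatter), both fall within the scatter, so the three compounds cannot be told apart on these data.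

Compound 4 `O=C(NC(=S)NNc1ncnc2ccccc12)c1ccccc1F` differs from compound 3 by fluoro in place of chloro on an aromatic carbon. Among the compounds with values here, no measured step swaps chloro for fluoro. Within the data shown here, the only step in which fluoro enters, a 1.8-fold lower number from compound 1 to compound 2 (0.27 log units; within the scatter), is small and at another position. The expected step is therefore a 1.2-fold lower number from compound 3 to compound 4 (0.08 log units; within the scatter), nothing beyond the scatter. Compound 4 is estimated at 9000 nM, with a range from 4500 nM to 18000 nM.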

Compound 4, half-maximal inhibitory concentration: 6460 nM
For compound 4 the middle estimate is 1.4-fold (0.14 log units) above the measured one; measured number inside the range.
By their numbers in this assay, from the lowest: compounds 2, 4, 3 and 1 (each within the scatter of the next).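

Fluoro in place of chloro on an aromatic carbon, ortho to a large group, gives a 1.7-fold lower number from compound 3 to compound 4 (0.22 log units; within the scatter) in this assay, so this site does not clearly tell the two atoms apart. The 2-fluorophenyl group also gives a 1.1-fold higher number from compound 2 to compound 4 (0.03 log units; within the scatter) against 4-fluorophenyl and a 1.7-fold lower number from compound 1 to compound 4 (0.24 log units; within the scatter) against 4-methylphenyl, so all the changes so far remain within the scatter. No further measurement bears on this result. From the compounds shown here alone, whether an amine or a carboxylic acid on this ring would shift the number beyond the scatter remains open.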